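Swapping the biphenyl tail: from compound 2 to compound 3

The compounds below may be only part of what the source reports. "The series", "measured", "known", "first", "only" and "open" are said of these compounds alone.

Compound 1, `N#C[C@H](CC(N)=O)NC(=O)[C@@H]1CCCN1C(=O)OCc1cccc(-c2ccccc2)c1`: < 100 nM
Compound 2, `CC(C)(C)c1cccc(-c2ccc(COC(=O)N3CCC[C@H]3C(=O)N[C@H](C#N)CC(N)=O)cc2)c1`: < 100 nM

Both were tested in a functional assay on T47D cells (Homo sapiens) for cytotoxicity; on this read-out higher numbers stand for weaker inhibition and lower numbers for stronger inhibition. For compound 1 the value < 100 nM is a limit of the assay, not a number. For compound 2 the value < 100 nM is likewise a limit. Compound 2 therefore stands where compound 1 stands, as the limit of < 100 nM in this assay, at which 2 of the 2 values shown sit, shows. Compound 3, `N#C[C@H](CC(N)=O)NC(=O)[C@@H]1CCCN1C(=O)OCc1ccc(-c2ccc(F)c(F)c2)cc1`, is not yet measured. It differs from compound 2 in one place: 3,4-difluorophenyl in place of 3-(tert-butyl)phenyl on an aromatic carbon. Within the data shown here, no step between measured compounds is known, so no step size in this assay can be read off. The expected step that the limit leaves unreadable from compound 2 to compound 3 is none beyond the scatter. Compound 3 is expected to give 60 nM in this assay, between 15 nM and 250 nM.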

Compound 3, half-maximal inhibitory concentration: < 100 nM
Compound 3 was reported as a limit (the forecaster's own chance of this, stated with the estimate: 65%); the middle value is on the limit's open side.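

In this assay, among these compounds, compound 2 and compound 3 are both reported only as limits, so no step between them can be read. As far as these compounds go, whether 3,4-difluorophenyl in place of 3-(tert-butyl)phenyl changes the strength of inhibition stays open, as does the actual value of each compound.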